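Swapping the acrylamide end for a bromoacetamide end

This account rests on a few compounds, and the source may have more. Where it says the series, first, only, none or still open, it means among the compounds named here.

Measured so far:
- compound 1, `CCCCC(=O)N(Cc1ccc(OC)c(O)c1)c1cc(OC)c(OC)c(OC)c1`: 170 nM
- compound 2, `COc1ccc(CN(C(=O)CO)c2cc(OC)c(OC)c(OC)c2)cc1O`: 520 nM
- compound 3, `C=CC(=O)N(Cc1ccc(OC)c(O)c1)c1cc(OC)c(OC)c(OC)c1`: 98 nM

All three share one core and differ only in the group on the carbonyl carbon of the amide. In a functional assay on HCT-116 cells (Homo sapiens) for inhibition, read by MTT assay, with a stated time of 48 h (on this read-out lower numbers stand for stronger inhibition and higher numbers for weaker inhibition), compound 3 gives the lowest number of the three. Its nearest neighbour is compound 1, with a 1.7-fold lower number from compound 1 to compound 3 (0.24 log units; within the scatter), a change within the scatter, so these two cannot be ranked. Compound 2 stands furthest away, with a 5.3-fold lower number from compound 2 to compound 3 (0.72 log units; beyond the scatter).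

Compound 4, `COc1ccc(CN(C(=O)CBr)c2cc(OC)c(OC)c(OC)c2)cc1O`, is the next step from compound 3, carrying (bromomethyl in place of vinyl on a carbonyl carbon). Going by the values given here, no measured step exchanges bromine for anything, so the closest guides are the two steps that lead into compound 3: one from a butyl group, within the scatter, and one from a hydroxymethyl group, beyond it. Compound 4 keeps a two-heavy-atom group on the carbonyl carbon, like compound 3, and so the expectation is a step of the small kind, a 1.3-fold higher number from compound 3 to compound 4 (0.12 log units; within the scatter), with no confident direction. Compound 4 is therefore estimated at 130 nM in this assay, within a range of 45 nM to 400 nM.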

Compound 4, half-maximal inhibitory concentration: 68 nM
The estimate for compound 4 lay 1.9-fold (0.28 log units) above the measured number; measured number inside the range.
By their numbers in this assay, from the lowest: compounds 4, 3 and 1 (each within the scatter of the next, the first and the last beyond it); then compound 2.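

In this assay, bromomethyl in place of vinyl on a carbonyl carbon gives a 1.4-fold lower number from compound 3 to compound 4 (0.16 log units; within the scatter), so these two compounds cannot be ranked, and among the compounds shown a double bond in this group is not needed to reach this level of the read-out. Compound 4 also stands clear of the butyl compound, with a 2.5-fold lower number from compound 1 to compound 4 (0.40 log units; beyond the scatter), a separation that the vinyl compound, compound 3, did not reach. The largest step among these four compounds is a 7.6-fold lower number from compound 2 to compound 4 (0.88 log units; beyond the scatter), and it comes from exchanging just hydroxy for bromo on a saturated chain carbon bound to a carbonyl carbon, so the atom carried on that carbon can matter as much as the size of the whole group.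

The compounds shown leave open how a chloromethyl, a plain methyl or an aminomethyl group on this carbonyl carbon would compare with bromomethyl and vinyl. Nothing shown here gives a measured reason for any of these differences.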